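Anilinopyrimidine ureas: a halogen-methoxy swap on the aniline

A few compounds are considered here, and "the series" means these few. Any claim that something is new, unique, unknown or untested is made for them only; others in the source may bear on it.

Working notes on three measured analogues and one open position. Compound 1 `CCc1ccc(Nc2cc(NC(=O)Nc3cc(OC)cc(OC)c3)ncn2)cc1` is the reference; in a functional assay on NCI-H226 cells (Homo sapiens) for inhibition, read by MTT assay, with a stated time of 48 h, tested at 10 uM (on this read-out lower numbers stand for less inhibition and higher numbers for more inhibition at the one concentration tested (going by the name of the read-out)), compound 1 gives 50.1%. Compound 2 `COc1cc(Br)ccc1Nc1cc(NC(=O)Nc2c(Cl)cccc2Cl)ncn1` gives 43% in this assay, and compound 3 `COc1cc(NC(=O)Nc2cc(Nc3cc(C(F)(F)F)ccc3OC)ncn2)cc(OC)c1` gives 60%. Compound 1 stands second highest of the three numbers; the gap to compound 2 and the gap to compound 3 are both within the usual scatter, so the three values cannot be ordered with any confidence. Going by the values given here, no pair among the measured compounds differs in only one place, so no clean step is available.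

The open position is compound 4 `COc1cc(NC(=O)Nc2cc(Nc3ccc(OC)c(I)c3)ncn2)cc(OC)c1`. Against compound 1 the change is 3-iodo-4-methoxyphenyl in place of 4-ethylphenyl on a nitrogen on an aromatic ring. The closest measured relative in the shared core is compound 3, whose aniline also carries a methoxy group, with a value of 60%. Among the compounds with values here, with no single-point step on record, the step from compound 1 to compound 4 is expected to be small and within the scatter, with at most a slight upward drift: a number 4.9 percentage points higher from compound 1 to compound 4 (within the scatter). Compound 4 is therefore estimated at 55%, with a range from 35% to 72%.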

Compound 4, a percentage reported as inhibition, at one concentration (the size of the read-out at that concentration, not a potency): 40.1%
For compound 4 the middle estimate is 14.9 percentage points above the measured one, and the stated range covers the measured number.
By their numbers in this assay, from the lowest: compounds 4, 2, 1 and 3 (each within the scatter of the next, the first and the last beyond it).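

In this assay, going by these compounds alone, the first one-place step, (4-ethylphenyl)amino to (3-iodo-4-methoxyphenyl)amino, gives a number 10 percentage points lower from compound 1 to compound 4 (within the scatter), so this exchange of aryl groups on the nitrogen does not move the read-out beyond the usual scatter. The position is not indifferent to its aryl group, however: compound 3 at 60% and compound 4 at 40.1% carry different aryl groups on that nitrogen in the same remaining structure, and their values lie beyond the scatter of each other. No measured evidence bears on the reason for either result.

The compounds shown do not separate the contribution of the iodine from that of the methoxy group. Also open, from the compounds shown here alone, is how a primary amine or a carboxylic acid on this aryl ring, or a longer alkyl chain in place of ethyl, would read.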